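The source may hold more compounds than are shown below. What is called first, only, known or untested is meant among the compounds shown, and "the series" means these compounds.

Measured so far in a functional assay on LOX IMVI cells (Homo sapiens) for inhibition, read by sulforhodamine B assay, with a stated time of 48 h; on this read-out higher numbers stand for weaker inhibition of growth and lower numbers for stronger inhibition of growth:
compound 1 `Nc1cc(N)c2nc(-c3ccccc3)c(Oc3ccc(Cl)c(Cl)c3)nc2c1`: 16200 nM
compound 3 `COc1ccc(CNc2nc3cc(N)cc(N)c3nc2-c2ccccc2)cc1`: 13500 nM
compound 2 `CCOC(=O)[C@H](CCC(=O)O)NC(=O)c1ccc(CNc2nc3cc(N)cc(N)c3nc2-c2ccccc2)cc1`: < 100000 nM

Among the compounds with values here, for compound 2 this last figure is only a limit of this assay, not a number, and it is the one value sitting at the limit of < 100000 nM in this assay, at which 1 of the 3 values shown sits. Of the two real numbers, compound 1 carries the higher one, but compound 1 and compound 3 lie within the usual scatter of each other, so the two numbers cannot be separated.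

The step from compound 1 to compound 4 `COc1ccc(Sc2nc3cc(N)cc(N)c3nc2-c2ccccc2)cc1` replaces the aryl ether: (4-methoxyphenyl)sulfanyl in place of 3,4-dichlorophenoxy on an aromatic carbon. The aryl group that enters carries the same 4-methoxyphenyl pattern that compound 3 carries on its benzylamine side chain, and compound 3 sits at 13500 nM in this assay. Within the data shown here, no measured pair covers a change of this kind, so the size of the step is an expectation only. The step of a 1.1-fold lower number from compound 1 to compound 4 (0.03 log units; within the scatter) is expected to be none beyond the scatter. Compound 4 is therefore estimated at 15000 nM, with a range from 5000 nM to 45000 nM.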

Compound 4, concentration for 50% growth inhibition: 51300 nM
The estimate for compound 4 lay 3.4-fold (0.53 log units) below the measured number; measured number outside the range, above it.
By their numbers in this assay, from the lowest: compounds 3 and 1 (each within the scatter of the next); then compound 4.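

In this assay, within the data shown here, the aromatic carbon next to the ring nitrogen is the first place where a single change can be read: (4-methoxyphenyl)sulfanyl in place of 3,4-dichlorophenoxy gives a 3.2-fold higher number from compound 1 to compound 4 (0.50 log units; beyond the scatter). Growth inhibition therefore depends on the group at this position, and this change moves it towards weaker inhibition. The change swaps the linking atom and the ring substituents together, so the step cannot be divided between them, and nothing in the data at hand accounts for it.

Open, from the compounds shown here alone, is whether 4-methoxyphenoxy or (3,4-dichlorophenyl)sulfanyl would stay close to compound 1 or to compound 4, which would separate the linking atom from the ring substituents. Also open, going by these compounds, is how an amine or a carboxylic acid on the aryl ring would read at this position.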